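The source may report more compounds than this note shows. Statements on the series, on what has been measured and on what is new or still open speak of the compounds shown alone.

Of the compounds shown here, two have numbers so far in a functional assay on MCF7 cells (Homo sapiens) for antiproliferative activity, read by MTT assay, with stated times of 24 h and 72 h; on this read-out lower numbers stand for stronger inhibition and higher numbers for weaker inhibition. Compound 1 `COc1cc([C@@H]2[C@H](Oc3ccccc3)C(=O)N2c2cc(OC)c(OC)c(OC)c2)ccc1O` gives 32000 nM, and compound 2 `COc1cc(N2C(=O)[C@@H](Oc3ccccc3)[C@H]2c2ccc(O)c(O)c2)cc(OC)c1OC` gives 4500 nM, the lower of the two numbers. Next is compound 3 `COc1ccc([C@@H]2[C@H](Oc3ccccc3)C(=O)N2c2cc(OC)c(OC)c(OC)c2)cc1N`, which keeps the shared core and differs from compound 2 as follows: 3-amino-4-methoxyphenyl in place of 3,4-dihydroxyphenyl on a saturated ring carbon. This puts 3-amino-4-methoxyphenyl in place of 3,4-dihydroxyphenyl on a saturated ring carbon, next to the ring nitrogen.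

Among the compounds with values here, only one measured step bears on this change: a 7.1-fold lower number from compound 1 to compound 2 (0.85 log units; beyond the scatter), a modest step beyond the scatter, with hydrogen in place of methyl on an oxygen on an aromatic ring. It shows that this assay responds to a change in the group at this same place. Within the data shown here, no measured compound carries an amino group, so the direction rests on thin evidence. A modest step to a lower number is expected, with a wide margin either way. The expected change is a 3.0-fold lower number from compound 2 to compound 3 (0.48 log units; beyond the scatter). Compound 3 is estimated at 1500 nM, with an expected range of 150 nM to 15000 nM.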

Compound 3, half-maximal inhibitory concentration: 12200 nM
For compound 3 the middle estimate is 8.1-fold (0.91 log units) below the measured one; the measured number falls inside the stated range.
By their numbers in this assay, from the lowest: compound 2; then compound 3; then compound 1.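

On the saturated ring carbon next to the ring nitrogen, 3-amino-4-methoxyphenyl gives an intermediate result in this assay, with a 2.7-fold higher number from compound 2 to compound 3 (0.43 log units; beyond the scatter) and a 2.6-fold lower number from compound 1 to compound 3 (0.42 log units; beyond the scatter). The amino-bearing ring therefore does not match 3,4-dihydroxyphenyl here, but it does give a lower number than 4-hydroxy-3-methoxyphenyl, so the earlier loss on moving from the catechol to a methoxy-bearing ring is not the whole picture at this position. Nothing available here accounts for this order among the three aryl groups.

Both new steps change the two ring substituents together, so the contribution of the amino group cannot be separated from that of the relocated methoxy group. From the compounds shown here alone, a 3-hydroxy-4-methoxyphenyl or a 3-amino-4-hydroxyphenyl group at this position would separate the two effects, and a 3-dimethylaminophenyl group would test whether the amine hydrogens matter, while the effect of replacing the phenoxy group on the neighbouring ring atom also remains open.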